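The source may report more compounds than this note shows. Statements on the series, on what has been measured and on what is new or still open speak of the compounds shown alone.

Compound 2 `CS(=O)(=O)c1ccc([C@@H](CC(=O)O)NC(=O)[C@@H]2CCCN2S(=O)(=O)c2cc(Cl)cc(Cl)c2)cc1` gives the lowest of the two numbers measured in an assay on RPMI-8866 cells for inhibition of integrin alpha-4/beta-1 (Homo sapiens) (a lower number here means a stronger inhibitor, a higher number a weaker inhibitor), at 0.55 nM. Among the measured compounds shown here, its only neighbour, compound 1 `C/C=C/[C@@H](CC(=O)O)NC(=O)[C@@H]1CCCN1S(=O)(=O)c1cc(Cl)cc(Cl)c1`, gives 13 nM in this assay, and the single measured step, a 24-fold lower number from compound 1 to compound 2 (1.37 log units; beyond the scatter), came with 4-(methylsulfonyl)phenyl in place of prop-1-en-1-yl on a saturated chain carbon bound to an amide-type nitrogen and a saturated chain carbon. Compound 3 `O=C(O)C[C@@H](NC(=O)[C@@H]1CCCN1S(=O)(=O)c1cc(Cl)cc(Cl)c1)c1ccc(OC2CC2)cc1` has not yet been measured. It differs from compound 2 by cyclopropyloxy in place of methylsulfonyl on an aromatic carbon. For the measured compounds named here, no measured step touches only the group on this aromatic ring: the step from compound 1 to compound 2 exchanged the whole prop-1-en-1-yl for the 4-(methylsulfonyl)phenyl group, so it shows that this aryl group carries a large share of the potency of compound 2, but not how much of that rests on the methylsulfonyl part. Because compound 2 at 0.55 nM stands far from the number of compound 1, compound 3 is expected to give a somewhat higher number in this assay, a step of a 3.6-fold higher number from compound 2 to compound 3 (0.56 log units; beyond the scatter). The estimate for compound 3 in this assay is 2 nM, within 0.4 nM to 15 nM.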

Compound 3, half-maximal inhibitory concentration: 0.85 nM
Compound 3: middle estimate off by 2.4-fold (0.37 log units), on the high side, within the range that was stated.
By their numbers in this assay, from the lowest: compounds 2 and 3 (each within the scatter of the next); then compound 1.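

In this assay, the replacement of methylsulfonyl by cyclopropyloxy gives a 1.5-fold higher number from compound 2 to compound 3 (0.19 log units; within the scatter), so the low number of compound 2 does not depend on the methylsulfonyl group in particular: a group without sulfur, carrying a three-membered ring of carbon, gives a number that cannot be told apart from it. The large advantage over the prop-1-en-1-yl group of compound 1 also appears with the second aryl group, as a 15-fold lower number from compound 1 to compound 3 (1.18 log units; beyond the scatter), which shows that this advantage is not tied to a single group at this place on the ring. Nothing at hand explains why two groups with such different atoms give such close numbers.

The compounds shown leave open whether the para position, as printed for this place, needs any group at all, since a plain phenyl ring does not appear among them. Going by these compounds, they also leave open how an amine, a carboxylic acid or a longer alkoxy chain such as butoxy would fare at this place on the ring, so the limits of what is tolerated here remain unknown.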